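The compounds below may be only part of what the source reports. "The series", "measured", "known", "first", "only" and "open" are said of these compounds alone.

Compound 1 `CO[C@@H](C(=O)NC1CC[C@@H](OC(=O)c2ccccc2)CNC1=O)[C@H](O)[C@@H](O)[C@H](O)/C=C/C(C)(C)C` gives 370 nM in an in vivo functional assay on the whole organism (MDA-MB-435 cells, Homo sapiens) for antiproliferative activity (a higher number here means a weaker inhibitor, a lower number a stronger inhibitor), the higher of the two numbers measured. Compound 2 `CO[C@@H](C(=O)NC1CC[C@@H](OC(=O)CC2CCCCC2)CNC1=O)[C@H](O)[C@@H](O)[C@H](O)/C=C/C(C)(C)C` gives 60 nM, and the change a 6.2-fold lower number from compound 1 to compound 2 (0.79 log units; beyond the scatter) shows that altering the group on the carbonyl carbon can shift potency. Compound 3 `CCCCCCCCCCOc1ccc(C(=O)O[C@@H]2CCC(NC(=O)[C@H](OC)[C@H](O)[C@@H](O)[C@H](O)/C=C/C(C)(C)C)C(=O)NC2)cc1` differs from compound 1 by decyloxy in place of hydrogen on an aromatic carbon, a change at a different position, so that single step bears on it only loosely. Since the measured step shows the ester region tolerates change, a small to modest improvement is expected, with wide uncertainty. Compound 3 is expected to give about 200 nM, within 40 nM to 1000 nM. This expected change amounts to a 1.9-fold lower number from compound 1 to compound 3 (0.27 log units; within the scatter).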

Compound 3, half-maximal inhibitory concentration: 10 nM
For compound 3 the middle estimate is 20-fold (1.30 log units) above the measured one; measured number below the stated range.
By their numbers in this assay, from the lowest: compound 3; then compound 2; then compound 1.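

In this assay, adding decyloxy to the aromatic carbon para to a large group gives a 37-fold lower number from compound 1 to compound 3 (1.57 log units; beyond the scatter) and adds no ring. The earlier step changed only the group on the carbonyl carbon, whereas this one shows that the aromatic ring of compound 1 can itself carry a long chain and still give a lower number. Nothing given here explains this drop. The compounds shown leave open how much depends on chain length, and whether a shorter butoxy chain, or an amine at this same place, would give a similar number.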